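From 2-methoxyphenyl to tert-butyl: compound 3 to compound 4

A few compounds are considered here, and "the series" means these few. Any claim that something is new, unique, unknown or untested is made for them only; others in the source may bear on it.

Compound 1 `O=C1O/C(=C\Cn2cc(-c3ccc(Br)cc3)nn2)C(OCc2ccccc2)=C1OCc1ccccc1`: > 100000 nM
Compound 2 `CCCCCc1ccc(-c2cn(C[C@H](O)[C@H]3OC(=O)C(OCc4ccccc4)=C3OCc3ccccc3)nn2)cc1`: 13800 nM
Compound 3 `COc1ccccc1-c1cn(C[C@H](O)[C@H]2OC(=O)C(OCc3ccccc3)=C2OCc2ccccc2)nn1`: > 100000 nM

These results come from a functional assay on HCT-116 cells (Homo sapiens) for antiproliferative activity, read by MTT assay, with a stated time of 72 h; a higher number here means a weaker inhibitor, a lower number a stronger inhibitor. Compound 3 gives > 100000 nM, which is a limit and not a number. It sits at the limit of > 100000 nM in this assay, at which 2 of the 3 values shown sit, and only compound 2 has a true number. Compound 4 `CC(C)(C)c1cn(C[C@H](O)[C@H]2OC(=O)C(OCc3ccccc3)=C2OCc2ccccc2)nn1` carries tert-butyl in place of 2-methoxyphenyl on an aromatic carbon. Within the data shown here, the one measured step at this place is an at least 7.2-fold higher number from compound 2 to compound 3 (0.86 log units; beyond the scatter). Among the measured compounds shown here, it shows that this group can matter, but no measured compound carries tert-butyl. The expected step is an at least 1.2-fold lower number from compound 3 to compound 4 (0.09 log units; that floor lies within the scatter), so no change beyond the scatter is expected. Compound 4 is estimated at 80000 nM, with an expected range of 30000 nM to 200000 nM.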

Compound 4, half-maximal inhibitory concentration: 28300 nM
Estimate against measurement, compound 4: 2.8-fold (0.45 log units) above, and the stated range ends above it.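

In this assay, tert-butyl in place of 2-methoxyphenyl gives an at least 3.5-fold lower number from compound 3 to compound 4 (0.54 log units; beyond the scatter), so a six-membered aromatic ring at this position is not needed for a measurable value. Compound 3 stands at a limit, not a number: the limit of > 100000 nM in this assay, at which 2 of the 4 values shown sit. Tert-butyl in place of 4-pentylphenyl gives a 2.1-fold higher number from compound 2 to compound 4 (0.31 log units; beyond the scatter), a modest loss of potency.

The compounds shown leave open how a plain pentyl chain, with no ring, would behave at this position. Going by these compounds, how an amine or a carboxylic acid would behave there also remains open.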